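The source may report more compounds than this note shows. Statements on the series, on what has been measured and on what is new or still open speak of the compounds shown alone.

Within the data shown here, compound 2 `c1ccc(COc2ccc(COc3ccc(OCCOCCNC4CCCCC4)cc3)cc2)cc1` is the weaker of the two compounds measured so far: in a functional assay on SK-OV-3 cells (Homo sapiens) for inhibition, read by CCK-8 assay, with a stated time of 70 h (on this read-out higher numbers stand for weaker inhibition and lower numbers for stronger inhibition), compound 2 gives 8080 nM, whereas compound 1 `Clc1ccc(COc2ccc(OCCOCCNC3CCCCC3)cc2)cc1` gives 2650 nM; the only measured step, a 3.0-fold higher number from compound 1 to compound 2 (0.48 log units; beyond the scatter), concerns a different part of the molecule. Compound 3 `c1ccc(COc2ccc(COc3ccc(OCCOCCNC4CCCC4)cc3)cc2)cc1` differs from compound 2 in one place: cyclopentyl in place of cyclohexyl on an amine nitrogen. Among the measured compounds shown here, no measured step touches the cyclohexylamino group, so nothing here tells how this change acts; the expected step of a 1.0-fold lower number from compound 2 to compound 3 (0.00 log units; within the scatter) is therefore none beyond the scatter. Compound 3 is expected to give about 8000 nM in this assay, in a range from 3000 nM to 22000 nM.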

Compound 3, half-maximal inhibitory concentration: 10000 nM
Compound 3: the middle estimate sits 1.3-fold (0.10 log units) below what was measured, and the stated range covers the measured number.
By their numbers in this assay, from the lowest: compound 1; then compounds 2 and 3 (each within the scatter of the next).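

The step at the amine nitrogen, cyclopentyl in place of cyclohexyl, reads in this assay as a 1.2-fold higher number from compound 2 to compound 3 (0.09 log units; within the scatter). On the core of compound 2, then, these two rings cannot be told apart in this assay. No available evidence speaks to the reason for this result.

From the compounds shown here alone, whether a smaller ring such as cyclopropyl or an open chain such as isopropyl on this nitrogen would shift the number beyond the scatter remains open. So does whether cyclopentyl and cyclohexyl also match on the core of compound 1.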